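A few compounds are considered here, and "the series" means these few. Any claim that something is new, unique, unknown or untested is made for them only; others in the source may bear on it.

In an ADME assay on HEK293 cells (Homo sapiens) for cytotoxicity, read by MTT assay, with a stated time of 24 h (on this read-out higher numbers stand for weaker inhibition and lower numbers for stronger inhibition), compound 1 `COC(=O)c1scc(-c2ccc(NC(=O)c3cccc(I)c3)cc2)c1OC` gives 42700 nM. Compound 2 `COC(=O)c1scc(-c2ccc(NC(=O)c3ccc(C#N)nc3)cc2)c1OC` offers no number to start from, since its entry reads "not determined" (no result reported). The next structure is compound 3 `COC(=O)c1scc(-c2ccc(NC(=O)c3ccc(OC)nc3)cc2)c1OC`. The change leading to it is methoxy in place of cyano on an aromatic carbon, which puts methoxy in place of cyano on an aromatic carbon, next to the ring nitrogen. Among the compounds with values here, no measured step exists to guide the expectation, so the only anchor is compound 1 at 42700 nM, and no shift beyond the usual scatter from that value is expected, in either direction. Compound 3 is estimated at about 40000 nM, within a range of 15000 nM to 100000 nM.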

Compound 3, half-maximal inhibitory concentration: > 50000 nM
Compound 3: no number, only a limit; the forecaster's own chance of this, stated with the estimate: 20%; middle value at least 1.2-fold (0.09 log units) from the limit.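

Compound 3 gives only a limit of the assay, not a number: the limit of > 50000 nM in this assay, at which 1 of the 3 values shown sits. From the compounds shown here alone, replacing 3-iodophenyl with 6-methoxypyridin-3-yl gives an at least 1.1-fold higher number from compound 1 to compound 3 (0.06 log units; that floor lies within the scatter), so the two compounds cannot be told apart with confidence, and the true size of the step remains unknown. The step from cyano to methoxy cannot be read, as compound 2 has no result. Still open, going by these compounds, is how an amine or a carboxylic acid on the same aromatic carbon, next to the ring nitrogen, would read out, and whether either would give a measurable number.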